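The compounds below may be only part of what the source reports. "The series", "measured", "known", "first", "only" and "open" are said of these compounds alone.

Two compounds of this series have numbers in a functional assay on MKN-45 cells (Homo sapiens) for cytotoxicity, read by MTT assay, with a stated time of 72 h; on this read-out higher numbers stand for weaker inhibition and lower numbers for stronger inhibition. Compound 1 `Fc1ccc(Nc2cc(Nc3ccc(Oc4ccncc4-c4cccnc4)c(F)c3)ncn2)cc1` gives 160 nM. Compound 2 `O=C(Nc1ccc(Oc2ccncc2-c2cccnc2)c(F)c1)C1=NN(c2ccccc2C(F)(F)F)c2ccccc2S1(=O)=O` gives 27 nM, the lowest of the two numbers; the gap to compound 1 lies beyond the scatter. Within the data shown here, no pair of measured compounds differs in a single place, so the weight of any one change on the shared core is not yet known from measurement.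

Compound 3 `O=C(Nc1ccc(Oc2ccncc2-c2cccnc2)c(F)c1)C1=NN(c2cccc(F)c2)c2ccccc2S1(=O)=O` has not yet been tested in this assay. Compared with compound 2 it carries 3-fluorophenyl in place of 2-(trifluoromethyl)phenyl on a nitrogen on an aromatic ring in a ring. Among the measured compounds shown here, with no matched step to lean on, the step expected for a 1.5-fold higher number from compound 2 to compound 3 (0.17 log units; within the scatter) is small, within the scatter or at most slightly toward a higher number. Compound 3 is accordingly expected to give about 40 nM, with a range from 12 nM to 130 nM.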

Compound 3, half-maximal inhibitory concentration: 3 nM
For compound 3 the middle estimate is 13-fold (1.12 log units) above the measured one, and the stated range ends above it.
By their numbers in this assay, from the lowest: compound 3; then compound 2; then compound 1.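

In this assay this gives the series its first matched step: 3-fluorophenyl in place of 2-(trifluoromethyl)phenyl on the nitrogen gives a 9.0-fold lower number from compound 2 to compound 3 (0.95 log units; beyond the scatter) and so the group at this position clearly carries weight in the read-out. The change swaps one substituted phenyl for another, and the hydrogen-bond donor and acceptor counts of the two groups do not differ, so a change of this kind is enough to move the number beyond the scatter. Nothing measured on these compounds accounts for the step.

On these data alone, the step joins a change of substituent with a change of its place on the phenyl, so the share of each remains open. Unsubstituted phenyl or 3-(trifluoromethyl)phenyl at this position would begin to separate the two, and an aminophenyl group would test how far the trend extends.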